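Tert-butyl Amide in Place of the Morpholinyl Hydrazide

This account rests on a few compounds, and the source may have more. Where it says the series, first, only, none or still open, it means among the compounds named here.

Measured compounds:
compound 1, `Cc1cc(C(=O)O)nn1Cc1cc(Cl)cc2cc(C3CCCCC3)oc12`, 3.98 nM
compound 2, `Cc1cc(C(=O)NN2CCOCC2)nn1Cc1cc(Cl)cc2cc(-c3ccccc3)oc12`, 10 nM

In an assay on CHO-K1 cells for displacement of a labelled ligand from prostaglandin E2 receptor EP1 subtype (Homo sapiens), read by scintillation counting, with a stated time of 45 min (on this read-out higher numbers stand for weaker inhibition and lower numbers for stronger inhibition), compound 2 gives 10 nM, the higher of the two numbers measured; compound 1 gives 3.98 nM, and the gap between the two lies beyond the scatter. For the measured compounds named here, the two compounds differ in more than one place, so the comparison between them yields no single step.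

Compound 3, `Cc1cc(C(=O)NC(C)(C)C)nn1Cc1cc(Cl)cc2cc(-c3ccccc3)oc12`, has not yet been measured in this assay. The change from compound 2 is tert-butyl in place of morpholin-4-yl on an amide-type nitrogen. Going by the values given here, nothing among the measured compounds resolves this change on its own: compound 1 carries no amide at all, so no measured pair brackets it.

Compound 3 is therefore expected to land close to compound 2, with a step of a 1.2-fold higher number from compound 2 to compound 3 (0.08 log units; within the scatter) that is estimated to fall within the scatter, in either direction. The estimate for compound 3 in this assay is 12 nM, expected within 4 nM to 40 nM.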

Compound 3, half-maximal inhibitory concentration in the prostaglandin E2 receptor EP1 subtype assay: 10 nM
Beside the measured number, compound 3's estimate is 1.2-fold (0.08 log units) above it; the range from low to high includes it.
By their numbers in the prostaglandin E2 receptor EP1 subtype assay, from the lowest: compound 1; then compounds 2 and 3 (each within the scatter of the next).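

For the compounds shown here, in the prostaglandin E2 receptor EP1 subtype assay compound 2 gives 10 nM and compound 3 gives 10 nM, so there is no change at the digits printed from compound 2 to compound 3 (within the scatter), and this gives the first reading of a single change on the amide-type nitrogen, which compound 1, lacking any amide, could not provide. Morpholin-4-yl, with its six-membered non-aromatic ring and two hydrogen-bond acceptors, can thus be exchanged for tert-butyl, with no ring and no acceptors, without a difference beyond the scatter. In a physicochemical assay for lipophilicity, using the shake flask method, at pH 7.4 (a lower number here means a more polar compound, a higher number a more lipophilic compound), compound 2 gives 3 and compound 3 gives 2.9, which shows a number 0.10 log units lower from compound 2 to compound 3 (within the scatter) for the same exchange. No measurement shown here offers an explanation for these readings.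

The compounds shown leave open how other groups on this nitrogen would read, such as a methyl, a longer alkyl chain, or a chain ending in an amine or a carboxylic acid. They also leave open whether the same exchange would read alike on the core of compound 1.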